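This account rests on a few compounds, and the source may have more. Where it says the series, first, only, none or still open, it means among the compounds named here.

Measured so far:
Compound 1 `CN1C[C@H](NC(=O)OCCCCC2CCCCC2)C1=O` gives 1980 nM in an assay on HEK293 cells for inhibition of N-acylethanolamine-hydrolyzing acid amidase (Homo sapiens), read by fluorescence, with stated times of 10 min and 50 min; on this read-out lower numbers stand for stronger inhibition and higher numbers for weaker inhibition.
Compound 2 `CCCON1C(=O)[C@@H](NC(=O)OCCCCC2CCCCC2)[C@@H]1C` gives 133 nM in this assay.

Of these two numbers, compound 2 has the lower one, and the gap to compound 1 lies beyond the usual scatter of repeated measurements. For the measured compounds named here, compound 1 and compound 2 differ in more than one place at once, so no single structural step between them can be read from their values; they only show that the pair stand well apart.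

Compound 3 `C[C@H]1[C@H](NC(=O)OCCCCC2CCCCC2)C(=O)N1OCCCS(C)(=O)=O` differs from compound 2 in one place: methylsulfonyl in place of hydrogen on a saturated chain carbon, three bonds along the chain from an oxygen. The change sits at the far end of the chain, away from the shared core, while the carbamate, the ring and the methyl group remain as in compound 2. Going by the values given here, no measured pair shows a step of this kind, so the data give no size for it. The writer expects a step from compound 2 to compound 3 of a 1.2-fold higher number from compound 2 to compound 3 (0.08 log units; within the scatter), which would stay within the scatter, with no confident direction. For compound 3 the estimate in this assay is 160 nM, with a range from 50 nM to 500 nM.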

Compound 3, half-maximal inhibitory concentration: 49 nM
Compound 3: the middle estimate sits 3.3-fold (0.51 log units) above what was measured; measured number below the stated range.
By their numbers in this assay, from the lowest: compound 3; then compound 2; then compound 1.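

In this assay, replacing hydrogen with methylsulfonyl at the far end of the propyl chain gives a 2.7-fold lower number from compound 2 to compound 3 (0.43 log units; beyond the scatter), so this saturated chain carbon, three bonds along the chain from an oxygen, is sensitive to what it carries. Compound 1 and compound 2 differ in more than one place at once and could only show that they stand apart, whereas this pair gives the first size for a single change, and here the change lowers the number. Nothing available explains the size or direction of this step.

This single step cannot show whether the gain is specific to methylsulfonyl, or whether an amine, a carboxylic acid, a methoxy group or a simple amide at the same chain end would give a similar step, and a longer or shorter chain carrying methylsulfonyl also remains an open comparison. It also leaves open whether the 3-(methylsulfonyl)propyl group would lower the number to a similar extent on the core of compound 1, where the methyl group stands in place of the propyl chain's attachment.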